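Working notes: chloro to trifluoromethyl on compound 3

This account rests on a few compounds, and the source may have more. Where it says the series, first, only, none or still open, it means among the compounds named here.

compound 1 `Cc1ccc(-c2nc(C)c(COc3ccc4c(c3)OCC4CC(=O)O)s2)cc1` gives 73.5 nM in a functional assay on CHO cells for agonist activity at Free fatty acid receptor 1 (Homo sapiens), read by FLIPR and calcium flux; on this read-out higher numbers stand for an effect only at larger amounts of compound and lower numbers for an effect already at smaller amounts
compound 2 `Cc1nc(-c2ccccc2Cl)sc1COc1ccc2c(c1)OCC2CC(=O)O` gives "not determined" (no result reported) in this assay
compound 3 `Cc1nc(-c2ccc(Cl)cc2)sc1COc1ccc2c(c1)OCC2CC(=O)O` gives 85.6 nM in this assay

Within the data shown here, only two numbers are in hand. Compound 3 and compound 1 lie within the scatter of each other, as the step of a 1.2-fold higher number from compound 1 to compound 3 (0.07 log units; within the scatter) shows, so compound 3 cannot be set apart from compound 1 on this read-out; compound 2 contributes no number.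

Compound 4 `Cc1nc(-c2ccc(C(F)(F)F)cc2)sc1COc1ccc2c(c1)OCC2CC(=O)O` differs from compound 3 by trifluoromethyl in place of chloro on an aromatic carbon. Among the measured compounds shown here, the one measured step that bears on this site, a 1.2-fold higher number from compound 1 to compound 3 (0.07 log units; within the scatter), exchanged one small group for another on that aromatic carbon and stayed within the scatter. For the measured compounds named here, no measured step covers trifluoromethyl itself, so the expectation rests on that single comparison alone. A step of about a 1.1-fold higher number from compound 3 to compound 4 (0.02 log units; within the scatter) is expected, that is, nothing beyond the scatter. For compound 4 the estimated value in this assay is 90 nM, with a range from 35 nM to 250 nM.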

Compound 4, half-maximal effective concentration: 96.7 nM
Beside the measured number, compound 4's estimate is 1.1-fold (0.03 log units) below it, and the stated range covers the measured number.
By their numbers in this assay, from the lowest: compounds 1, 3 and 4 (each within the scatter of the next).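

Trifluoromethyl, with 4 heavy atoms where chloro has 1, extends the comparison at this aromatic carbon, para to a large group, and this assay still shows no difference beyond the scatter: a 1.1-fold higher number from compound 3 to compound 4 (0.05 log units; within the scatter), and a 1.3-fold higher number from compound 1 to compound 4 (0.12 log units; within the scatter). The earlier compounds shown here covered only methyl and chloro here, whereas methyl, chloro and trifluoromethyl now all lie within the scatter of one another, so this read-out does not separate the three groups at this position. No measurement is available that would account for this result.

Whether an amine, a carboxylic acid or a methoxy group at this position would stay within the scatter of these compounds remains open, as does a plain hydrogen on this carbon. Changes elsewhere on the shared core also remain open.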